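The source may report more compounds than this note shows. Statements on the series, on what has been measured and on what is new or still open speak of the compounds shown alone.

Compound 1, `COc1ccccc1NC(=S)N/N=C/c1ccc2ccccc2n1`, gives > 100000 nM in a functional assay on SGC-7901 cells (Homo sapiens) for antiproliferative activity, read by sulforhodamine B assay, with a stated time of 72 h (a lower number here means a stronger inhibitor, a higher number a weaker inhibitor), which is a limit of the assay rather than a number.
Compound 2, `NC(=S)N/N=C/c1cc2ccccc2s1`, gives > 100000 nM in this assay, again a limit.
Compound 3, `Cc1ccc(NC(=O)N/N=C/c2ccc3ccccc3n2)cc1`, gives > 100000 nM in this assay, again a limit.

Compound 1 thus stands at the limit of > 100000 nM in this assay, at which 3 of the 3 values shown sit, and none of the three measured compounds yields a number that could be compared with another. Going by the values given here, no step between measured compounds is available, so there is nothing here that shows how any single structural change shifts potency.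

The unmeasured compound 4, `Fc1ccc(NC(=S)N/N=C/c2ccc3ccccc3n2)cc1`, differs from compound 1 in one place only: 4-fluorophenyl in place of 2-methoxyphenyl on an amide-type nitrogen. The shared core and the thiourea linker are kept.

Because compound 1 gives only > 100000 nM, compound 4 is expected to remain at or close to that same limit. The expected step that the limit leaves unreadable from compound 1 to compound 4 is estimated to be none beyond the scatter, in either direction. Compound 4 is therefore estimated at about 150000 nM, with a range from 30000 nM to 600000 nM, and most likely the assay will again report only a limit.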

Compound 4, half-maximal inhibitory concentration: 32300 nM
Estimate against measurement, compound 4: 4.6-fold (0.67 log units) above, and the stated range covers the measured number.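

Going by these compounds alone, the group on the amide-type nitrogen turns out to matter: in this assay, 4-fluorophenyl in place of 2-methoxyphenyl gives an at least 3.0-fold lower number from compound 1 to compound 4 (0.49 log units; beyond the scatter), the first change in this set that can be seen at all, as the earlier compounds offered no step to read. Going by these compounds, the true size of this step stays unknown, as it starts from a limit and not from a number, so it can only be read as a minimum, and the real change could be larger. Compound 4 is also the only compound here with an actual number, which gives later changes a measured starting point that the others could not provide, as they stop at the assay's limit: the limit of > 100000 nM in this assay, at which 3 of the 4 values shown sit.

The compounds shown leave open whether the drop in the number follows from adding the fluorine, from losing the methoxy group, or from the different place of the substituent on the phenyl ring. A plain phenyl group, or a phenyl ring carrying an amine or a carboxylic acid, on the same nitrogen would be needed to tell how far this position can go, and the evidence here gives no cause for the step.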